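Series notes: bromo replaced by 4-methoxyphenyl

A few compounds are considered here, and "the series" means these few. Any claim that something is new, unique, unknown or untested is made for them only; others in the source may bear on it.

Measured so far in an assay on CHO cells for displacement of a labelled ligand from adenosine receptor A3 (Homo sapiens), read by scintillation counting, tested at 10 uM; a higher number here means more inhibition at the concentration tested (going by the name of the read-out), a lower number less inhibition:
- compound 1, `CC(C)(C)Cc1c(Br)sc(N)c1C(=O)c1ccc(Cl)cc1`: 1%
- compound 2, `CC(C)(C)Cc1c(Br)sc(N)c1C(=O)c1cccc(Cl)c1`: 1%
- compound 3, `CC(C)(C)Cc1c(Br)sc(N)c1C(=O)c1cccc(C(F)(F)F)c1`: 4%

Compound 2 sits level with compound 1 at the digits printed, and the two together are the lowest of the three numbers; compound 3 is nearest above it, the gap being within the scatter. The two measured steps are no change at the digits printed from compound 1 to compound 2 (within the scatter) and a number 3 percentage points higher from compound 2 to compound 3 (within the scatter). Both alter the aryl on the carbonyl carbon and leave the rest of the shared core untouched, so all three compounds read as essentially flat in this assay.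

Compound 4, `COc1ccc(-c2sc(N)c(C(=O)c3cccc(Cl)c3)c2CC(C)(C)C)cc1`, differs from compound 2 at a different place: 4-methoxyphenyl in place of bromo on an aromatic carbon. Going by the values given here, neither measured step touches this position, so nothing bears directly on it; the only guidance is that every measured value lies low and the two steps show no movement. The step of a number 11 percentage points higher from compound 2 to compound 4 (beyond the scatter) is therefore expected to be small, with a wide band to cover the unknown. For compound 4 the estimate in this assay is 12%, ranging from 0% to 50%.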

Compound 4, a percentage reported as inhibition, at one concentration (the size of the read-out at that concentration, not a potency): 2%
Beside the measured number, compound 4's estimate is 10 percentage points above it, and the stated range covers the measured number.
By their numbers in this assay, from the lowest: compounds 1, 2, 4 and 3 (each within the scatter of the next).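

In this assay the position next to the ring sulfur now has a measured step: 4-methoxyphenyl in place of bromo gives a number 1 percentage points higher from compound 2 to compound 4 (within the scatter) and leaves compound 4 not separated from compound 2. Here 8 heavy atoms, with a six-membered aromatic ring and a hydrogen-bond acceptor, enter where 1 heavy atom leaves, so this place joins the aryl on the carbonyl carbon as a site where the one change shown gives no reading beyond the scatter. Nothing available explains this result.

The compounds shown leave open whether an amine or a carboxylic acid at this position, or a longer chain in place of the neopentyl group, would lift the number in this assay out of this low range. They also leave open whether 4-methoxyphenyl reads the same with the carbonyl aryl of compound 1 or compound 3.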